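The source may report more compounds than this note shows. Statements on the series, on what has been measured and on what is new or still open speak of the compounds shown alone.

Working notes on the series. Two members have been run in an assay on membranes from liver for displacement of a labelled ligand from Sigma intracellular receptor 2 (Rattus norvegicus), read by scintillation counting, with a stated time of 120 min; on this read-out lower numbers stand for stronger inhibition and higher numbers for weaker inhibition. Compound 1 `COc1cc2c(cc1OC)CN(CCCC(=O)c1c(C)c(OC)c(OC)c(OC)c1OC)CC2` carries a four-carbon linker between the shared core and the ketone; in this assay compound 1 gives 5.1 nM. Compound 2 `COc1cc2c(cc1OC)CN(CCCCC(=O)c1c(C)c(OC)c(OC)c(OC)c1OC)CC2` extends that linker by one carbon; in this assay compound 2 gives 3 nM. Of the two numbers, compound 2 has the lower one, yet its gap to compound 1 falls within the usual scatter, so the two values are read as equivalent and no order between them is claimed.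

Compound 3 `COc1cc2c(c(OC)c1OC)CCN(CCCCC(=O)c1c(C)c(OC)c(OC)c(OC)c1OC)C2` keeps the five-carbon linker and the ketone-bearing ring of compound 2 unchanged and alters only the shared core: methoxy in place of hydrogen on an aromatic carbon. No comparable change has been measured in this set, so nothing here says how this assay responds to an added methoxy on that ring. With the rest of the molecule intact, the expectation is a step in this assay of no more than the scatter, in no fixed direction; the estimate for the step is a 1.3-fold higher number from compound 2 to compound 3 (0.12 log units; within the scatter). Compound 3 is accordingly estimated at 4 nM, with the range running from 1.5 nM to 12 nM.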

Compound 3, inhibition constant: 34.2 nM
Estimate against measurement, compound 3: 8.6-fold (0.93 log units) below; the measured number lies above the stated range.
By their numbers in this assay, from the lowest: compounds 2 and 1 (each within the scatter of the next); then compound 3.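

For the compounds shown here, this aromatic carbon of the shared core, ortho to a fused ring and ortho to a methoxy group, is the first place where a single change moves the number in this assay clearly: methoxy in place of hydrogen gives an 11-fold higher number from compound 2 to compound 3 (1.06 log units; beyond the scatter), a large step, whereas compound 1 and compound 2, which differ in linker length, stand within the scatter of each other. The entering group is small, with two heavy atoms and no net charge, so this read-out is sensitive to substitution at this carbon, at least with the linker of compound 2 in place. Nothing available accounts for the size of this step.

A single substituent at a single carbon cannot show whether the step belongs to methoxy as such; a fluorine, a methyl or a hydroxyl on the same carbon would bear on that. From the compounds shown here alone, whether the added methoxy gives a step of similar size on the shorter linker of compound 1 also stays open.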